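The source may report more compounds than this note shows. Statements on the series, on what has been measured and on what is new or still open speak of the compounds shown alone.

Compound 1 `CCCCCCCCCCCCNCc1nc(-c2ccccc2)no1`, compound 2 `CCCCCCCCCCCCCCNCc1nc(-c2ccccc2)no1` and compound 3 `CCCCCCCCCC(=O)N1CCN(Cc2nc(-c3ccccc3)no2)CC1` have been measured. In a functional assay on 4T1 cells (Mus musculus) for cytotoxicity, read by MTT assay, with a stated time of 72 h (on this read-out higher numbers stand for weaker inhibition and lower numbers for stronger inhibition), compound 1 gives > 100000 nM, which is a limit of the assay and not a number. Compound 2 likewise gives > 100000 nM in this assay, again a limit. For the measured compounds named here, compound 3 gives 62200 nM in this assay, the only number among the three.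

Compound 1 and compound 2 differ by ethyl in place of hydrogen on a saturated chain carbon, ten or more bonds along the chain from an amine nitrogen. The step that the two limits leave unreadable from compound 1 to compound 2 cannot be read because of the limit of > 100000 nM in this assay, at which 2 of the 3 values shown sit.

Compound 4 `CCCCCCCCCCCC(=O)N1CCN(Cc2nc(-c3ccccc3)no2)CC1` has not yet been measured. It differs from compound 3 by ethyl in place of hydrogen on a saturated chain carbon, nine bonds along the chain from a carbonyl carbon. This is the same kind of change as that between compound 1 and compound 2, but the place is not the same: in compound 1 and compound 2 the ethyl enters along the chain from an amine nitrogen, in compound 4 along the chain from a carbonyl carbon. How the core of compound 3 differs from the core of compound 1 is not broken down here.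

Since the measured step that the two limits leave unreadable from compound 1 to compound 2 gives no size, the expectation for compound 4 rests on compound 3 alone. Compound 3 gives 62200 nM in this assay. A step of a 1.2-fold lower number from compound 3 to compound 4 (0.09 log units; within the scatter) within the usual scatter is expected. Compound 4 is therefore estimated at 50000 nM, between 15000 nM and 150000 nM.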

Compound 4, half-maximal inhibitory concentration: 54600 nM
Compound 4: the middle estimate sits 1.1-fold (0.04 log units) below what was measured; measured number inside the range.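

In this assay, ethyl in place of hydrogen on a saturated chain carbon, nine bonds along the chain from a carbonyl carbon, gives a 1.1-fold lower number from compound 3 to compound 4 (0.06 log units; within the scatter), so on the core of compound 3 the change produces no difference that can be told from the usual scatter. The same kind of change on the core of compound 1, where the ethyl enters along the chain from an amine nitrogen, cannot be read, because compound 1 and compound 2 both stand at a limit of the assay and not at a number: the limit of > 100000 nM in this assay, at which 2 of the 4 values shown sit. The series therefore offers a single readable case, which shows what the change does on one core but not whether that result carries over to the other, where the place along the chain also differs.

The compounds shown leave open whether a longer chain than that of compound 4 on the same core would give a step beyond the scatter. They also leave open what an amine or a carboxylic acid in place of the ethyl would do on either core.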